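Anilide chain homologation on two pyrimidine cores

A few compounds are considered here, and "the series" means these few. Any claim that something is new, unique, unknown or untested is made for them only; others in the source may bear on it.

Measured so far in a functional assay on MCF7 cells (Homo sapiens) for antiproliferative activity, read by MTT assay, with a stated time of 72 h; a lower number here means a stronger inhibitor, a higher number a weaker inhibitor:
- compound 1, `CC/C=C/C(=O)Nc1cccc(Oc2nc(Nc3ccn(C)n3)nc3c2CSCC3)c1`: > 50000 nM
- compound 2, `CCC/C=C/C(=O)Nc1cccc(Oc2nc(Nc3ccn(C)n3)nc3c2CSCC3)c1`: 22600 nM
- compound 3, `CC/C=C/C(=O)Nc1cccc(Oc2nc(Nc3ccc(OC)cc3)nc3c2CSCC3)c1`: 31400 nM

The value given for compound 1 is a limit of this assay, not a number; it is the limit of > 50000 nM in this assay, at which 1 of the 3 values shown sits.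

Two cores are present. Compound 3 differs from compound 1 by 4-methoxyphenyl in place of 1-methyl-1H-pyrazol-3-yl on a nitrogen on an aromatic ring; that change gives an at least 1.5-fold lower number from compound 1 to compound 3 (0.20 log units; that floor lies within the scatter). Compound 3 and compound 2 sit close to each other in this assay, and nothing here separates them.

On the core of compound 1, the change methyl in place of hydrogen on a saturated chain carbon, two bonds along the chain from a double-bonded chain carbon gives an at least 2.2-fold lower number from compound 1 to compound 2 (0.34 log units; beyond the scatter). Because compound 1 sits at the limit of > 50000 nM in this assay, at which 1 of the 3 values shown sits, only a floor for that step is known.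

Compound 4, `CCC/C=C/C(=O)Nc1cccc(Oc2nc(Nc3ccc(OC)cc3)nc3c2CSCC3)c1`, is not yet measured in this assay. It differs from compound 3 by methyl in place of hydrogen on a saturated chain carbon, two bonds along the chain from a double-bonded chain carbon. The place of this change is the same as that between compound 1 and compound 2, so this is the same change on the other core. The expectation for compound 4 therefore rests on the step of an at least 2.2-fold lower number from compound 1 to compound 2 (0.34 log units; beyond the scatter) and on the value of compound 3, 31400 nM. Going by the values given here, only one measured example of this change exists, and its size is known only as a floor, so the range is kept wide. Compound 4 is expected to give 14000 nM in this assay, between 5000 nM and 40000 nM. The step from compound 3 to compound 4 that this estimate means is a 2.2-fold lower number from compound 3 to compound 4 (0.35 log units; beyond the scatter), expected to be of a size comparable to the floor seen from compound 1 to compound 2.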

Compound 4, half-maximal inhibitory concentration: > 50000 nM
Compound 4 gave a limit, no number (the forecaster's own chance of this, stated with the estimate: 10%); middle value at least 3.5-fold (0.55 log units) from the limit.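

In this assay compound 4 gives > 50000 nM, which is a limit of the assay and not a number. The change from but-1-en-1-yl to pent-1-en-1-yl gives an at least 1.5-fold higher number from compound 3 to compound 4 (0.20 log units; that floor lies within the scatter), which taken alone does not go beyond the scatter, yet it does not repeat the lower number seen on the core of compound 1, and the two steps differ: the same change on two cores in this assay, an at least 2.2-fold lower number (0.34 log units; beyond the scatter) from compound 1 to compound 2 and an at least 1.5-fold higher number (0.20 log units; that floor lies within the scatter) from compound 3 to compound 4, at least 3.5-fold (0.54 log units) apart, beyond the scatter of two such steps The exchange of the group on the nitrogen between the two pent-1-en-1-yl compounds gives an at least 2.2-fold higher number from compound 2 to compound 4 (0.34 log units; beyond the scatter), so the chain change cannot be carried from one core to the other as a fixed increment, but every step here touching a limit is only a floor, the true size of the gap stays unread, and a single pair of cores gives no rule for the series: the same change on two cores in this assay, an at least 1.5-fold lower number (0.20 log units; that floor lies within the scatter) from compound 1 to compound 3 and an at least 2.2-fold higher number (0.34 log units; beyond the scatter) from compound 2 to compound 4, at least 3.5-fold (0.54 log units) apart, beyond the scatter of two such steps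

The compounds shown leave open how a longer chain than pent-1-en-1-yl, or a chain ending in an amine or a carboxylic acid, would read on either core in this assay. They also leave open whether a plain phenyl on that nitrogen would follow the pattern of the 4-methoxyphenyl group or that of the 1-methyl-1H-pyrazol-3-yl group.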